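A few compounds are considered here, and "the series" means these few. Any claim that something is new, unique, unknown or untested is made for them only; others in the source may bear on it.

Measured compounds:
Compound 1, `Cc1ccc2oc(-c3ccc(NC(=O)CN4CCN(CCCN(C)C)CC4)cc3)nc2c1`, in a functional assay on MCF7 cells (Homo sapiens) for cytotoxicity, read by MTT assay, with a stated time of 24 h; on this read-out lower numbers stand for stronger inhibition and higher numbers for weaker inhibition: 19100 nM
Compound 2, `Cc1cc(-c2nc3cc(Cl)ccc3o2)ccc1NC(=O)CCl`, in this assay: > 100000 nM, a limit of the assay and not a number

Of the two values shown, only compound 1 carries a number, 19100 nM. Compound 2 stands at the limit of this assay and is recorded as > 100000 nM, which is a limit and not a measured number. This is the limit of > 100000 nM in this assay, at which 1 of the 2 values shown sits. Compound 2 therefore gives no fixed starting point from which a step can be counted.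

Compound 3, `Cc1cc(-c2nc3ccccc3o2)ccc1NC(=O)CCl`, has not yet been measured. It differs from compound 2 in one place: hydrogen in place of chloro on an aromatic carbon. Going by the values given here, no step between measured compounds is recorded here, so the size of this change in this assay cannot be read from any measured pair. The expected step from compound 2 to compound 3, a step that the limit leaves unreadable from compound 2 to compound 3, is taken as none beyond the scatter. Compound 3 is accordingly expected to come out near 120000 nM, within a range from 40000 nM to 400000 nM, with a good chance that the assay again reports only a limit rather than a number.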

Compound 3, half-maximal inhibitory concentration: 29800 nM
For compound 3 the middle estimate is 4.0-fold (0.60 log units) above the measured one, and the stated range ends above it.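

In this assay, hydrogen in place of chloro on this aromatic carbon, meta to a fused ring and para to a fused ring, goes with an at least 3.3-fold lower number from compound 2 to compound 3 (0.52 log units; beyond the scatter). Compound 2 is recorded as > 100000 nM, which is a limit of the assay and not a number. The earlier compounds offered no pair differing in one place, so this is the only change whose direction can be read here, and the size of the step is bounded on one side only: the limit of > 100000 nM in this assay, at which 1 of the 3 values shown sits.

The compounds shown leave open whether the step is particular to chloro or whether other groups on this aromatic carbon, such as fluoro, methoxy or an amine, would fall on the side of hydrogen or on the side of chloro. Also open, going by these compounds, is whether the same exchange would give a step of similar size on a core carrying the longer amine-bearing side chain of compound 1 in place of the chloroacetamide end.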